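Cyclopropyl in place of cyclobutyl on the carbonyl carbon

A few compounds are considered here, and "the series" means these few. Any claim that something is new, unique, unknown or untested is made for them only; others in the source may bear on it.

compound 1 `C[C@@H]1C[C@H]1C(=O)N1CCN(c2nc(-c3cnn(C)c3)ncc2C#N)C[C@H]1C`: 54 mL/min/kg
compound 2 `C[C@@H]1CN(c2nc(-c3cnn(C)c3)ncc2C#N)CCN1C(=O)C1(C)CC1`: < 36 mL/min/kg
compound 3 `C[C@@H]1CN(c2nc(-c3cnn(C)c3)ncc2C#N)CCN1C(=O)C1CCC1`: < 36 mL/min/kg

In an ADME assay on microsomes from liver (Rattus norvegicus) for pharmacokinetics (a lower number here means slower removal, a higher number faster removal of the compound), compound 3 gives < 36 mL/min/kg, which is a limit and not a number. Compound 3 shares with compound 2 (the limit of < 36 mL/min/kg in this assay, at which 2 of the 3 values shown sit). Compound 4 `C[C@@H]1CN(c2nc(-c3cnn(C)c3)ncc2C#N)CCN1C(=O)C1CC1` carries cyclopropyl in place of cyclobutyl on a carbonyl carbon. The measured steps at this carbonyl carbon are an at least 1.5-fold lower number from compound 1 to compound 2 (0.17 log units; that floor lies within the scatter) and an at least 1.5-fold lower number from compound 1 to compound 3 (0.17 log units; that floor lies within the scatter), while the third is a step that the two limits leave unreadable from compound 2 to compound 3. None of them shows a change beyond the scatter. The expected outcome in this assay is therefore no step beyond the scatter, estimated as a step that the limit leaves unreadable from compound 3 to compound 4. Compound 4 is expected at an estimated 30 mL/min/kg (range 16 mL/min/kg to 54 mL/min/kg) .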

Compound 4, clearance: < 36 mL/min/kg
Compound 4: only a limit was reported; the forecaster's own chance of this, stated with the estimate: 70%; the middle value is on the limit's open side.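

In this assay, the three-membered cyclopropyl ring on the carbonyl carbon also gives a limit, not a number, so this position now holds three small rings that read alike. Hydrogen in place of methyl on a saturated ring carbon gives an at least 1.5-fold lower number from compound 1 to compound 4 (0.17 log units; that floor lies within the scatter). The steps among compound 2, compound 3 and compound 4 cannot be read, because all three values are limits: the limit of < 36 mL/min/kg in this assay, at which 3 of the 4 values shown sit.

As far as these compounds go, the numbers behind these limits stay open. Also open, from the compounds shown here alone, is whether an amine or a carboxylic acid on this carbonyl carbon, or a longer chain, would give a readable value.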